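The compounds below may be only part of what the source reports. "The series", "measured", "known", "first", "only" and "open" are said of these compounds alone.

Measured so far:
Compound 1 `CCCCCCCCN(C)C(=O)Cn1cc(Cc2cnc(OC)nc2)c(=O)nc1SCc1ccc(F)cc1`: 13%
Compound 2 `CCCCCCCCN(C)C(=O)Cn1cc(Cc2cnc(=O)n(CCO)c2)c(=O)nc1SCc1ccc(F)cc1`: 36%

In a functional assay on a cell-free system (plasma, Oryctolagus cuniculus) for inhibition of platelet-activating factor acetylhydrolase (Homo sapiens), tested at 100 nM (a higher number here means more inhibition at the concentration tested (going by the name of the read-out), a lower number less inhibition), compound 2 holds the higher of the two numbers; the step of a number 23 percentage points higher from compound 1 to compound 2 (beyond the scatter) lies beyond the scatter. Compound 3 `CCCCCCCCN(C)C(=O)Cn1cc(Cc2cnc(=O)n(CC(=O)NC)c2)c(=O)nc1SCc1ccc(F)cc1` keeps that higher-reading arrangement and differs from compound 2 only by methylcarbamoyl in place of hydroxymethyl on a saturated chain carbon bound to an aromatic nitrogen. Going by the values given here, no measured step touches this part of the molecule; the one step known changed a group on a saturated chain carbon bound to an aromatic carbon, so it gives no direct guide. With one hydrogen-bond donor and one acceptor leaving and entering alike, the expected step of no change at the digits printed from compound 2 to compound 3 (within the scatter) is small, and compound 3 is estimated at 36%, within 15% to 58%.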

Compound 3, a percentage reported as inhibition, at one concentration (the size of the read-out at that concentration, not a potency): 42%
The estimate for compound 3 lay 6 percentage points below the measured number; the measured number falls inside the stated range.
By their numbers in this assay, from the lowest: compound 1; then compounds 2 and 3 (each within the scatter of the next).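

In this assay the move to methylcarbamoyl on this saturated chain carbon bound to an aromatic nitrogen gives a number 6 percentage points higher from compound 2 to compound 3 (within the scatter) and so cannot be told apart from hydroxymethyl here, even though the entering group is larger. The reading stays clear of compound 1, with a number 29 percentage points higher from compound 1 to compound 3 (beyond the scatter) beyond the scatter as well. Nothing measured here explains why these two groups read alike.

Going by these compounds, whether a carboxylic acid or an amine at this place would read the same remains open. So does the effect of a longer chain carrying the methylcarbamoyl group.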